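The source may report more compounds than this note shows. Statements on the series, on what has been measured and on what is new or still open speak of the compounds shown alone.

Values in a functional assay on NCI-H1299 cells (Homo sapiens) for antiproliferative activity, read by fluorescence and resazurin assay, with a stated time of 48 h; on this read-out higher numbers stand for weaker inhibition and lower numbers for stronger inhibition:
- Compound 1 `COc1cccc(Cn2cc(-c3ccc(O)cc3)c(-c3ccc(O)cc3)c2)c1`: 25300 nM
- Compound 2 `COc1ccc(Cn2cc(-c3ccc(O)cc3)c(-c3ccc(O)cc3)c2)cc1OC`: 29200 nM

Compound 2 stands level with compound 1, the two values lying within the scatter of each other. Compound 3 `COc1ccc(Cn2cc(-c3ccc(O)cc3)c(-c3ccc(O)cc3)c2)c(OC)c1OC` derives from compound 2 through (methoxy in place of hydrogen on an aromatic carbon), methoxy in place of hydrogen on an aromatic carbon. Among the measured compounds shown here, the only measured step of this kind is a 1.2-fold higher number from compound 1 to compound 2 (0.06 log units; within the scatter). This single precedent gives no reason to expect a shift beyond the scatter in this assay, in either direction. The estimated change is a 1.0-fold higher number from compound 2 to compound 3 (0.01 log units; within the scatter). For compound 3 the expected value is 30000 nM, with an estimated range of 16000 nM to 55000 nM.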

Compound 3, half-maximal inhibitory concentration: 25100 nM
Compound 3: middle estimate off by 1.2-fold (0.08 log units), on the high side, within the range that was stated.
By their numbers in this assay, from the lowest: compounds 3, 1 and 2 (each within the scatter of the next).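

In this assay, methoxy in place of hydrogen ortho to a large group and ortho to a methoxy group gives a 1.2-fold lower number from compound 2 to compound 3 (0.07 log units; within the scatter). This second methoxy step, at a different place from the one in a 1.2-fold higher number from compound 1 to compound 2 (0.06 log units; within the scatter), also stays within the scatter, so neither place has yet moved the number beyond it. No available evidence bears on the result.

From the compounds shown here alone, whether an amine or a carboxylic acid at this position, or a longer chain in place of methoxy, would move the number beyond the scatter remains open. So does the contribution of the hydroxy groups on the shared core.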